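Closing the imidazole substituent into a ring at melanocortin receptor 4

The source may hold more compounds than are shown below. What is called first, only, known or untested is meant among the compounds shown, and "the series" means these compounds.

Compound 1 `COc1ccc(Br)cc1CCc1c(Cl)cccc1-c1nccn1C`: 300 nM in an assay on isolated protein for binding affinity to Melanocortin receptor 4 (Homo sapiens); a higher number here means a weaker inhibitor, a lower number a stronger inhibitor
Compound 2 `CCC(C)n1ccnc1-c1cccc(Cl)c1CCc1cc(Br)ccc1OC`: 2500 nM
Compound 3 `COc1ccc(Br)cc1CCc1c(Cl)cccc1-c1nccn1CC1CC1`: 2000 nM

Compound 3 stands second highest of the three numbers. The step of a 1.3-fold lower number from compound 2 to compound 3 (0.10 log units; within the scatter) lies within the scatter, whereas the step of a 6.7-fold higher number from compound 1 to compound 3 (0.82 log units; beyond the scatter) lies beyond it.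

Compound 4 `COc1ccc(Br)cc1CCc1c(Cl)cccc1-c1ncc2n1CCCC2` has the same atoms as compound 3, joined differently: a group of 9 heavy atoms (7 carbon, 2 nitrogen; one five-membered aromatic ring with 2 hetero atoms, one six-membered non-aromatic ring with 1 hetero atom) in place of a group of 9 heavy atoms (7 carbon, 2 nitrogen; one three-membered non-aromatic ring of carbon only, one five-membered aromatic ring with 2 hetero atoms), on an aromatic carbon. Among the compounds with values here, two measured steps bear on this change. Both an 8.3-fold higher number from compound 1 to compound 2 (0.92 log units; beyond the scatter) and a 6.7-fold higher number from compound 1 to compound 3 (0.82 log units; beyond the scatter) show that enlarging the group on the aromatic nitrogen beyond methyl gives a modestly higher number, while a 1.3-fold lower number from compound 2 to compound 3 (0.10 log units; within the scatter) shows that two groups of similar size on that nitrogen give numbers within the scatter of each other. Compound 4 keeps the same count of atoms as compound 3, so the expected step is small or none beyond the scatter: a 1.7-fold lower number from compound 3 to compound 4 (0.22 log units; within the scatter). Compound 4 is therefore estimated at 1200 nM, with a range from 400 nM to 4000 nM.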

Compound 4, inhibition constant: 340 nM
For compound 4 the middle estimate is 3.5-fold (0.55 log units) above the measured one; the whole stated range lies above it.
By their numbers in this assay, from the lowest: compounds 1 and 4 (each within the scatter of the next); then compounds 3 and 2 (each within the scatter of the next).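

Joining the same atoms into a six-membered non-aromatic ring, instead of leaving them as the open 1-(cyclopropylmethyl)-1H-imidazol-2-yl group, is not a neutral change in this assay: there is a 5.9-fold lower number from compound 3 to compound 4 (0.77 log units; beyond the scatter) and likewise a 7.4-fold lower number from compound 2 to compound 4 (0.87 log units; beyond the scatter), both beyond the scatter. The extra atoms alone therefore do not set the number at this position, since a 1.1-fold higher number from compound 1 to compound 4 (0.05 log units; within the scatter) and so the closed group stands level with the small methyl compound, while the two open groups do not. Nothing measured here accounts for this difference between the closed and open groups.

The compounds shown leave open whether a closed ring of another size would behave in the same way. They also leave open what an amine or a hydroxyl group on the six-membered non-aromatic ring would do to the number.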